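The compounds below may be only part of what the source reports. "The series", "measured", "known", "first", "only" and "open" are said of these compounds alone.

Of the compounds shown here, three sharing one core have been measured in a functional assay on MGC-803 cells (Homo sapiens) for inhibition, read by CCK-8 assay, with a stated time of 48 h; a higher number here means a weaker inhibitor, a lower number a stronger inhibitor. Compound 1 `COc1ccc(CN(C(=O)CSC(=S)N2CCN(C(=O)OC(C)(C)C)CC2)c2cc(OC)c(OC)c(OC)c2)cc1` gives 310 nM, compound 2 `COc1cc(N(Cc2ccc(Cl)cc2)C(=O)CSC(=S)N2CCN(C(=O)OC(C)(C)C)CC2)cc(OC)c1OC` gives 12900 nM, and compound 3 `COc1ccc(CN(C(=O)CSC(=S)N2CCN(C(=O)OC(C)(C)C)CC2)c2cc(OC)c(OC)c(OC)c2)cc1F` gives 4870 nM, the second highest number of the three. Compound 4 `COc1ccc(CN(C(=O)CSC(=S)N2CCN(C(=O)OC(C)(C)C)CC2)c2cc(OC)c(OC)c(OC)c2)cc1Br` differs from compound 3 by one exchange, bromo in place of fluoro on an aromatic carbon, ortho to a methoxy group.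

Going by the values given here, no measured pair makes this exchange. The nearest evidence is a 16-fold higher number from compound 1 to compound 3 (1.20 log units; beyond the scatter), a large step for fluoro in place of hydrogen on an aromatic carbon. Also relevant are a 42-fold higher number from compound 1 to compound 2 (1.62 log units; beyond the scatter), a large step for chloro in place of methoxy, and a 2.6-fold lower number from compound 2 to compound 3 (0.42 log units; beyond the scatter), a modest one. These steps show that both halogen-bearing compounds give higher numbers than compound 1, but none shows what swapping one halogen for another does. No step beyond the scatter is therefore expected, though the uncertainty is wide. The expected step is a 1.2-fold lower number from compound 3 to compound 4 (0.09 log units; within the scatter). For compound 4 the estimated value is 4000 nM, with an expected range from 800 nM to 15000 nM.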

Compound 4, half-maximal inhibitory concentration: 3710 nM
Beside the measured number, compound 4's estimate is 1.1-fold (0.03 log units) above it; the measured number falls inside the stated range.
By their numbers in this assay, from the lowest: compound 1; then compounds 4 and 3 (each within the scatter of the next); then compound 2.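

In this assay the two halogens on this aromatic carbon, ortho to a methoxy group, cannot be told apart, with a 1.3-fold lower number from compound 3 to compound 4 (0.12 log units; within the scatter) as the whole of the exchange. Bromo therefore joins fluoro in giving a much weaker inhibitor than hydrogen at this carbon, with a 12-fold higher number from compound 1 to compound 4 (1.08 log units; beyond the scatter) on record, so the large loss seen earlier is not confined to fluoro. The 3-bromo-4-methoxyphenyl group also stays ahead of the 4-chlorophenyl group, with a 3.5-fold lower number from compound 2 to compound 4 (0.54 log units; beyond the scatter) for that exchange, and nothing on hand explains any of these steps.

The compounds shown leave open whether chloro on this carbon would sit with fluoro and bromo. They also leave open whether a non-halogen group there, such as a methyl, a hydroxyl or an amine, would keep the strength of the hydrogen compound.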